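Biaryl in place of bromine on a propanoic acid agonist

This account rests on a few compounds, and the source may have more. Where it says the series, first, only, none or still open, it means among the compounds named here.

Of the compounds shown here, two have been measured in a functional assay on 1321-N1 cells for agonist activity at Free fatty acid receptor 1 (Homo sapiens), read by calcium flux; on this read-out lower numbers stand for an effect already at smaller amounts and higher numbers for an effect only at larger amounts of compound. Compound 1, `O=C(O)CCc1ccc(OCc2ccc(Br)cc2)cc1`, gives 550 nM. Compound 2, `O=C(O)CCc1ccc(NCc2cccc(Br)c2)cc1`, gives 174 nM. Of the two numbers, compound 2 holds the lower one, and the gap to compound 1 lies beyond the scatter of this assay.

The next compound, compound 3, `Cc1ccc(-c2cccc(CNc3ccc(CCC(=O)O)cc3)c2)cc1`, differs from compound 2 in a single place: 4-methylphenyl in place of bromo on an aromatic carbon. Among the measured compounds shown here, no pair of measured compounds shows this same change, so there is no measured step to lean on. The author expects the step from compound 2 to compound 3 to run toward lower numbers in this assay, by a margin larger than the scatter, as a 2.9-fold lower number from compound 2 to compound 3 (0.46 log units; beyond the scatter). Compound 3 is therefore estimated at 60 nM, with a range from 15 nM to 250 nM.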

Compound 3, half-maximal effective concentration: 126 nM
Beside the measured number, compound 3's estimate is 2.1-fold (0.32 log units) below it; measured number inside the range.
By their numbers in this assay, from the lowest: compounds 3 and 2 (each within the scatter of the next); then compound 1.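

In this assay, putting 4-methylphenyl in place of bromo on this aromatic carbon gives a 1.4-fold lower number from compound 2 to compound 3 (0.14 log units; within the scatter), so the two compounds cannot be told apart on this read-out. This position, meta to a large group, therefore takes a whole added six-membered aromatic ring of carbon only, seven heavy atoms where bromo had one, with no change in the number that exceeds the scatter. Nothing measured here bears on why the number holds across so large a change.

Going by these compounds, it remains open whether this holds for a plain phenyl without the methyl, or for a pyridine ring at the same place. The compounds shown also leave open what a methoxy group, a fluorine or a carboxylic acid on the added ring would do.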